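Removing a Methoxy Group: Growth Inhibition in Myeloma Cells

The source may hold more compounds than are shown below. What is called first, only, known or untested is meant among the compounds shown, and "the series" means these compounds.

Of the compounds shown here, two built on one shared core have been tested in a functional assay on RPMI-8226 cells (Homo sapiens) for inhibition, read by sulforhodamine B assay, with a stated time of 48 h, tested at 10 uM; on this read-out higher numbers stand for more inhibition of growth at the one concentration tested and lower numbers for less inhibition of growth. Compound 1 `c1ccc(-c2nc3sc(-c4ccccc4)cn3n2)cc1` carries two plain phenyl rings; in this assay compound 1 gives 14%. Compound 2 `COc1ccc(-c2nc3sc(-c4ccc(Cl)cc4)cn3n2)cc1` carries a methoxy group on one phenyl ring and a chlorine on the other; in this assay compound 2 gives 55.1%, the higher of the two numbers, and its distance from compound 1 lies beyond the scatter. Compound 1 and compound 2 differ in two places at once; the two values alone do not show how much of the gap belongs to each group. Compound 3 `Clc1ccc(-c2cn3nc(-c4ccccc4)nc3s2)cc1` keeps the chlorine but has hydrogen in place of methoxy on an aromatic carbon. Among the measured compounds shown here, with no single-change step available to guide the guess, a moderate decrease in this assay is expected, a number 20.1 percentage points lower from compound 2 to compound 3 (beyond the scatter). Compound 3 is thus expected to give 35%, with a range from 15% to 55%.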

Compound 3, percent growth inhibition at one concentration: 10%
Compound 3: the middle estimate sits 25 percentage points above what was measured; measured number outside the range, below it.
By their numbers in this assay, from the lowest: compounds 3 and 1 (each within the scatter of the next); then compound 2.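

In this assay, putting hydrogen in place of methoxy on this aromatic carbon, with the chlorine kept, gives a number 45.1 percentage points lower from compound 2 to compound 3 (beyond the scatter), a large step that shows this position is sensitive to the change when the chlorine is present. The second single change, chloro in place of hydrogen on an aromatic carbon with no methoxy present, gives a number 4 percentage points lower from compound 1 to compound 3 (within the scatter), so on its own the chlorine brings no readable difference, and the methoxy change is the only one of the two single steps that registers. Nothing available here explains why the methoxy group counts for so much at this position.

Still open, from the compounds shown here alone, is what methoxy does on the core of compound 1 when no chlorine is present, which would show whether the two groups need each other. Also open, going by these compounds, is whether an amine or an ethoxy group at this position would keep the growth inhibition seen with compound 2.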